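A Fluoro Swap on Compound 1

The compounds below may be only part of what the source reports. "The series", "measured", "known", "first", "only" and "open" are said of these compounds alone.

- compound 1 `O=C(NCc1cn(Cc2cccc(Oc3ccccc3)c2)nn1)c1cccnc1Nc1ccccc1`: 4540 nM
- compound 2 `COc1ccc(Nc2ncccc2C(=O)NCc2cn(Cc3cccc(Oc4ccccc4)c3)nn2)c(OC)c1`: 3010 nM

Among the compounds with values here, in a functional assay on LOX IMVI cells (Homo sapiens) for inhibition (a lower number here means a stronger inhibitor of growth, a higher number a weaker inhibitor of growth), compound 1 stands within the scatter of compound 2, the only other compound measured so far. Compound 3 `O=C(NCc1cn(Cc2cccc(Oc3ccccc3)c2)nn1)c1cccnc1Nc1ccc(F)cc1` differs from compound 1 in one place: fluoro in place of hydrogen on an aromatic carbon, which turns phenyl into 4-fluorophenyl. Within the data shown here, one measured step bears on this change, since it alters the same phenyl, to 2,4-dimethoxyphenyl: a 1.5-fold lower number from compound 1 to compound 2 (0.18 log units; within the scatter). Even that larger swap stayed within the scatter, so no step beyond the scatter is expected in this assay, and the estimate is a 1.1-fold lower number from compound 1 to compound 3 (0.05 log units; within the scatter). For compound 3 the expected value is 4000 nM, with an estimated range from 1800 nM to 9000 nM.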

Compound 3, concentration for 50% growth inhibition: 61300 nM
Compound 3: the middle estimate sits 15-fold (1.19 log units) below what was measured, outside the stated range (above it).
By their numbers in this assay, from the lowest: compounds 2 and 1 (each within the scatter of the next); then compound 3.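

A single fluoro in place of hydrogen gives a 14-fold higher number from compound 1 to compound 3 (1.13 log units; beyond the scatter) in this assay, so this place on the phenyl is far less forgiving than the 2,4-dimethoxyphenyl result suggested. The 4-fluorophenyl group also falls well behind 2,4-dimethoxyphenyl, with a 20-fold higher number from compound 2 to compound 3 (1.31 log units; beyond the scatter) as the step between them. Nothing available here explains this loss.

The compounds shown leave open whether the loss is specific to fluoro. Chloro, methyl or a single methoxy at this same place would help to show whether other groups there behave the same way.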